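This account rests on a few compounds, and the source may have more. Where it says the series, first, only, none or still open, it means among the compounds named here.

Measured compounds:
- compound 1, `O=C(/C=C/c1ccc(F)cc1)NS(=O)(=O)c1ccc(Cl)cc1`: 2.6 ug/mL
- compound 2, `O=C(/C=C/c1ccc(Cl)cc1)NS(=O)(=O)c1ccccc1`: 2.2 ug/mL
- compound 3, `O=C(/C=C/c1ccc(Cl)cc1)NS(=O)(=O)c1ccc(F)cc1`: 2 ug/mL

All three values come from a functional assay on B16-F10 cells (Mus musculus) for antiproliferative activity, read by ELISA and MTT assay, with a stated time of 48 h; a higher number here means a weaker inhibitor, a lower number a stronger inhibitor. Compound 3 gives the lowest number of the three, but its gaps to compound 2 and to compound 1 both lie within the scatter of this assay, so the three compounds cannot be told apart on these numbers. Among the compounds with values here, the one measured step that changes only one place, a 1.1-fold lower number from compound 2 to compound 3 (0.04 log units; within the scatter), is small and within the scatter.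

Compound 4, `O=C(/C=C/c1ccc(Cl)cc1)NS(=O)(=O)c1ccc(Cl)cc1`, has not yet been measured. It differs from compound 3 in one place: chloro in place of fluoro on an aromatic carbon. Within the data shown here, no measured step exchanges fluoro for chloro on that ring. Compound 1 carries chloro at that place, with fluoro on the other ring, and its value sits within the scatter of compound 3. Among the measured compounds shown here, the only step that bears on this change, from compound 2 to compound 3, added a fluoro at the same place and moved the number by less than the scatter. On that basis no step beyond the scatter is expected in this assay for compound 4 in either direction. Compound 4 is therefore estimated at 2.2 ug/mL, with a range from 1.2 ug/mL to 4 ug/mL. The expected step, a 1.1-fold higher number from compound 3 to compound 4 (0.04 log units; within the scatter), should stay within the scatter.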

Compound 4, half-maximal inhibitory concentration: 2.5 ug/mL
Estimate against measurement, compound 4: 1.1-fold (0.06 log units) below; measured number inside the range.
By their numbers in this assay, from the lowest: compounds 3, 2, 4 and 1 (each within the scatter of the next).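

Exchanging fluoro for chloro at this place, the 4-fluorophenyl to 4-chlorophenyl change, can now be read directly in this assay (a 1.3-fold higher number from compound 3 to compound 4 (0.10 log units; within the scatter)), and the two halogens cannot be told apart there. Chloro in place of hydrogen at the same place gives the same picture (a 1.1-fold higher number from compound 2 to compound 4 (0.06 log units; within the scatter)), and together with the earlier step for fluoro in place of hydrogen (a 1.1-fold lower number from compound 2 to compound 3 (0.04 log units; within the scatter)), this shows that hydrogen, fluoro and chloro all read alike at this position. The same exchange on the other aromatic ring also stays within the scatter (a 1.0-fold lower number from compound 1 to compound 4 (0.02 log units; within the scatter)), so among these compounds neither ring responds to it in a way this assay can detect.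

Nothing independent of these numbers is available to explain this flat result. The compounds shown carry only hydrogen, fluoro or chloro at these places, which leaves open whether a different group there, such as an amine, a carboxylic acid or a methoxy group, would shift the number beyond the scatter.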